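The source may hold more compounds than are shown below. What is called first, only, known or untested is meant among the compounds shown, and "the series" means these compounds.

Compound 1, with the structure `Cn1ncc(Cl)c1-c1cc(C(=O)N[C@@H]2CN[C@H](CCN3CCCCC3)C[C@H]2c2ccc(Cl)c(Cl)c2)oc1Cl`, was tested in a functional assay on OVCAR-8 cells (Homo sapiens) for antiproliferative activity (on this read-out higher numbers stand for weaker inhibition and lower numbers for stronger inhibition), and gave 1660 nM, the higher of the two numbers measured here. Compound 2, with the structure `CNC(=O)C[C@@H]1C[C@@H](c2ccc(F)c(F)c2)[C@H](NC(=O)c2cc(-c3c(Cl)cnn3C)c(Cl)o2)CN1`, gave 800 nM in this assay, a lower number that lies beyond the usual scatter of such measurements. Compound 3, with the structure `Cn1ncc(Cl)c1-c1cc(C(=O)N[C@@H]2CN[C@H](CC(=O)NCCO)C[C@H]2c2ccc(Cl)c(Cl)c2)oc1Cl`, has not yet been measured; it differs from compound 1 in one place: (2-hydroxyethyl)carbamoyl in place of (piperidin-1-yl)methyl on a saturated chain carbon bound to a saturated ring carbon. For the measured compounds named here, no measured pair shows the effect of this change, so only a modest step is expected; the step from compound 1 to compound 3 is estimated at a 1.7-fold lower number from compound 1 to compound 3 (0.22 log units; within the scatter). Compound 3 is therefore expected to give about 1000 nM, between 300 nM and 3500 nM.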

Compound 3, half-maximal inhibitory concentration: 1450 nM
Beside the measured number, compound 3's estimate is 1.5-fold (0.16 log units) below it; measured number inside the range.
By their numbers in this assay, from the lowest: compounds 2, 3 and 1 (each within the scatter of the next, the first and the last beyond it).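

In this assay, (2-hydroxyethyl)carbamoyl in place of (piperidin-1-yl)methyl on a saturated chain carbon bound to a saturated ring carbon gives a 1.1-fold lower number from compound 1 to compound 3 (0.06 log units; within the scatter). This place on the core of compound 1 therefore takes two quite different groups, one with a six-membered non-aromatic ring and one with no ring and a carbonyl, without a difference beyond the scatter. From the compounds shown here alone, whether a carboxylic acid, a primary amine or a longer chain would give the same picture stays open. Nothing measured here gives a reason for this result.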